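The source may hold more compounds than are shown below. What is called first, only, known or untested is meant among the compounds shown, and "the series" means these compounds.

Measured so far:
compound 1 `CCc1nc2c(C)cc(C)nc2n1Cc1ccc(OC(C(=O)O)c2ccccc2Cl)cc1` gives 15000 nM in an assay on Midbrain with Type-2 angiotensin II receptor (Rattus norvegicus) as the target; on this read-out higher numbers stand for weaker inhibition and lower numbers for stronger inhibition
compound 2 `CCCCc1cc(Cn2c(CC)nc3c(C)cc(C)nc32)ccc1OC(C(=O)O)c1ccccc1` gives 140 nM in this assay

Compound 2 stands lowest of the two numbers in this assay; its nearest neighbour is compound 1, whose number is higher by a gap that lies well beyond the scatter. Compound 1 and compound 2 differ in more than one place, so the two values only show the gap, and no single change can be read from it.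

Compound 3 `CCc1nc2c(C)cc(C)nc2n1Cc1ccc(OC(C(=O)O)c2ccccc2)c(Cc2ccccc2)c1` has not yet been measured in this assay. It differs from compound 2 by phenyl in place of propyl on a saturated chain carbon bound to an aromatic carbon, or, read one bond further out, butyl to benzyl.

Going by the values given here, no step between measured compounds speaks to this change, so there is no direct guide to its size. Compound 2 is expected to keep most of its standing, with compound 3 estimated near 200 nM in this assay, within 50 nM to 800 nM, a step of a 1.4-fold higher number from compound 2 to compound 3 (0.15 log units; within the scatter) that is expected to stay close to or just beyond the scatter.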

Compound 3, half-maximal inhibitory concentration: 800 nM
Estimate against measurement, compound 3: 4.0-fold (0.60 log units) below, within the range that was stated.
By their numbers in this assay, from the lowest: compound 2; then compound 3; then compound 1.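

In this assay, going by these compounds alone, the swap of butyl for benzyl gives a 5.7-fold higher number from compound 2 to compound 3 (0.76 log units; beyond the scatter) and is the first change in this set that can be read on its own, since it alters a single place. It shows that this saturated chain carbon bound to an aromatic carbon is sensitive to what it carries: phenyl in place of propyl moves the result towards weaker inhibition by more than the scatter, though the step is only modest in size. Nothing measured here bears on why the number rises, so the step stands as an observation without an explanation.

One step at one place cannot tell whether the rise follows from the aromatic ring itself or from the loss of the propyl part of the chain, and a cyclohexylmethyl group or a longer chain such as pentyl at the same place would separate these two readings. On these data alone, how an amine or a carboxylic acid carried at the end of this chain would shift the number also remains open.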